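Compound 2 to compound 3: one group exchanged

The compounds below may be only part of what the source reports. "The series", "measured", "known", "first", "only" and "open" are said of these compounds alone.

Values so far in a functional assay on a cell-free system (plasma, Homo sapiens), with a stated time of 3 min; a higher number here means a weaker inhibitor, a lower number a stronger inhibitor
- Compound 1 `CCCC[C@@H](O)C(=O)N1C[C@H]2C[C@H]2[C@H]1C(=O)NCc1cc(Cl)ccc1-n1cnnn1` gives 750 nM
- Compound 2 `COC(C)(C)[C@@H](O)C(=O)N1C[C@H]2C[C@H]2[C@H]1C(=O)NCc1cc(Cl)ccc1-n1cnnn1` gives 1000 nM

Compound 2 with 1000 nM lies within the usual scatter of compound 1, so these two values cannot be ranked. Compound 3 `CC1(C[C@@H](O)C(=O)N2C[C@H]3C[C@H]3[C@H]2C(=O)NCc2cc(Cl)ccc2-n2cnnn2)CC1` keeps the shared core but carries (1-methylcyclopropyl)methyl in place of 1-methoxy-1-methylethyl on a saturated chain carbon bound to a carbonyl carbon and an oxygen on a saturated carbon. Within the data shown here, only one measured step bears on this place. It is a 1.3-fold higher number from compound 1 to compound 2 (0.12 log units; within the scatter) when 1-methoxy-1-methylethyl replaces butyl, and it stays within the scatter. One small step is thin evidence, but it gives no reason to expect a large move in this assay here. The expected step is a 1.4-fold lower number from compound 2 to compound 3 (0.15 log units; within the scatter) and nothing beyond the scatter is foreseen. The estimate for compound 3 is 700 nM (expected range 250 nM to 2000 nM).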

Compound 3, half-maximal inhibitory concentration: 500 nM
Beside the measured number, compound 3's estimate is 1.4-fold (0.15 log units) above it; low and high end bracket the measured number.
By their numbers in this assay, from the lowest: compounds 3, 1 and 2 (each within the scatter of the next).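

In this assay, putting the all-carbon (1-methylcyclopropyl)methyl in place of 1-methoxy-1-methylethyl gives a 2.0-fold lower number from compound 2 to compound 3 (0.30 log units; within the scatter). This position therefore accepts a three-membered carbon ring, and the loss of the ether oxygen with its hydrogen-bond acceptor, without any step beyond the scatter. Setting 1-methylcyclopropyl in place of propyl gives a 1.5-fold lower number from compound 1 to compound 3 (0.18 log units; within the scatter), so closing part of the chain into a ring also leaves the reading within the scatter, and no measurement at hand accounts for how close these values lie.

With every step within the scatter, the three groups at this position cannot be ranked. As far as these compounds go, whether an amine, a carboxylic acid or a much longer chain at this place would move the number beyond the scatter remains open.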